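The compounds below may be only part of what the source reports. "The series", "measured", "known", "first", "only" and "open" are said of these compounds alone.

This piece follows one change made to compound 2 `COc1cc(NC(C)CCCNC(=O)NCc2ccncc2)c2ncccc2c1` and what it may do to potency. In a functional assay on MOLT-4 cells (Homo sapiens), read by MTT assay, with a stated time of 72 h (a higher number here means a weaker inhibitor, a lower number a stronger inhibitor), compound 2 gives 24000 nM. Its companion, compound 1 `COc1cc(NC(C)CCCNC(=O)NC(c2ccccc2)c2ccccc2)c2ncccc2c1`, stands apart. In this assay compound 1 reaches only a limit of the test, >= 500000 nM, which is not a number. Going by the values given here, of the two values shown, compound 2 holds the only real number, while the other sits at the limit (the limit of >= 500000 nM in this assay, at which 1 of the 2 values shown sits). Compound 3 `COc1cc(NC(C)CCCNC(=O)NCc2ccccc2)c2ncccc2c1` has not yet been measured. It differs from compound 2 in one place: phenyl in place of pyridin-4-yl on a saturated chain carbon bound to an amide-type nitrogen. Among the compounds with values here, no measured pair shows this change, and only an expectation can be offered: a step of modest size, within or just beyond the usual scatter, with no firm direction. Compound 3 is expected to come in near 30000 nM, somewhere between 8000 nM and 120000 nM. That would mean an expected step of a 1.3-fold higher number from compound 2 to compound 3 (0.10 log units; within the scatter).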

Compound 3, half-maximal inhibitory concentration: 21000 nM
For compound 3 the middle estimate is 1.4-fold (0.15 log units) above the measured one; measured number inside the range.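

In this assay, phenyl in place of pyridin-4-yl on a saturated chain carbon bound to an amide-type nitrogen gives a 1.1-fold lower number from compound 2 to compound 3 (0.06 log units; within the scatter), so at this place the read-out does not separate a ring of carbon only from a ring with one hetero atom. Going by these compounds alone, the one large change comes instead from hydrogen in place of phenyl on a saturated chain carbon bound to an amide-type nitrogen and an aromatic carbon, which gives an at least 23-fold lower number from compound 1 to compound 3 (1.37 log units; beyond the scatter), so a second phenyl at this place and a hydrogen do not read alike. That step starts from a limit of the test and not from a number, and the limit belongs to compound 1: the limit of >= 500000 nM in this assay, at which 1 of the 3 values shown sits.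

Going by these compounds, what remains open is how a single ring at this place would read with a carboxylic acid or an amine attached to it. A longer chain leading to the ring, or pyridin-2-yl in place of phenyl, is also left open by the compounds shown.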